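Replacing the methoxyphenyl on the side chain of compound 2

The source may hold more compounds than are shown below. What is called first, only, known or untested is meant among the compounds shown, and "the series" means these compounds.

Measured so far:
Compound 1 `CCCCCC/C=C/C[C@H]1C[C@@H]([C@@H](O)c2ccccc2)CO[C@@H]1c1ccccc1` gives 4990 nM in a functional assay on HL-60 cells (Homo sapiens) for cytotoxicity, read by WST assay, with a stated time of 48 h; on this read-out lower numbers stand for stronger inhibition and higher numbers for weaker inhibition.
Compound 2 `COc1ccccc1/C=C/C[C@H]1C[C@@H]([C@@H](O)c2ccccc2)CO[C@@H]1c1ccccc1` gives 10100 nM in this assay.

For the measured compounds named here, compound 2 therefore holds the highest, that is the weakest, of the two numbers; the only neighbour is compound 1, and the step of a 2.0-fold higher number from compound 1 to compound 2 (0.31 log units; beyond the scatter) lies beyond the usual scatter but is still modest. Compound 3 `O[C@@H](c1ccccc1)[C@H]1CO[C@H](c2ccccc2)[C@@H](C/C=C/c2ccncc2)C1` has not yet been measured. It differs from compound 2 in one place: pyridin-4-yl in place of 2-methoxyphenyl on a double-bonded chain carbon bound to a double-bonded chain carbon.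

Going by the values given here, only one measured step exists, and it bears on this change indirectly at most: it shows that exchanging hexyl for 2-methoxyphenyl at the same place moved the number modestly upward. Nothing measured shows how a pyridin-4-yl behaves there. With both groups being a single six-membered aromatic ring, the step of a 1.2-fold higher number from compound 2 to compound 3 (0.07 log units; within the scatter) is expected to stay small, most likely within the scatter, leaning if anything toward a slightly higher number. Compound 3 is accordingly estimated at 12000 nM, with a range from 5000 nM to 30000 nM.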

Compound 3, half-maximal inhibitory concentration: > 100000 nM
Compound 3 gave a limit, no number; the forecaster's own chance of this, stated with the estimate: 10%; middle value at least 8.3-fold (0.92 log units) away from the limit.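

In this assay compound 3 gives a limit of the assay and not a number: the limit of > 100000 nM in this assay, at which 1 of the 3 values shown sits. Putting pyridin-4-yl in place of 2-methoxyphenyl gives an at least 9.9-fold higher number from compound 2 to compound 3 (0.99 log units; beyond the scatter), so at this place on the side chain, one six-membered aromatic ring cannot simply stand in for another, even though the two rings look alike on paper. For the compounds shown here, measured against hexyl, the same ring gives an at least 20-fold higher number from compound 1 to compound 3 (1.30 log units; beyond the scatter), whereas the earlier exchange of hexyl for 2-methoxyphenyl gave only a 2.0-fold higher number from compound 1 to compound 2 (0.31 log units; beyond the scatter), which makes pyridin-4-yl the one group of the three that sets itself far apart here.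

The step from compound 2 to compound 3 removes the methoxy group and brings a nitrogen into the ring in a single move, so these three compounds cannot say which of the two changes accounts for the loss. A plain phenyl on the same chain carbon would separate those two changes, while pyridin-3-yl or pyridin-2-yl would test whether the location of the ring nitrogen matters at all.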